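The compounds below may be only part of what the source reports. "The series", "measured", "known", "first", "only" and "open" are said of these compounds alone.

Working notes on the series. Three members of the shared core carry different groups on the carbonyl carbon attached to the piperidine nitrogen. Compound 1 `CN(C)CC(=O)N1CCC(NS(=O)(=O)c2cc(S(=O)(=O)c3ccccc3)ccc2C(F)(F)F)CC1` gives 280 nM in a functional assay on U2OS cells for antagonist activity at proto-oncogene Wnt-3 (Homo sapiens), read by a luciferase reporter, with a stated time of 18 h; a higher number here means that more compound is needed for the effect, a lower number that less compound is needed. Compound 2 `CC(=O)N1CCC[C@H]1C(=O)N1CCC(NS(=O)(=O)c2cc(S(=O)(=O)c3ccccc3)ccc2C(F)(F)F)CC1` gives 250 nM, and compound 3 `O=C([C@@H]1CCCN1C(=O)c1ccncc1)N1CCC(NS(=O)(=O)c2cc(S(=O)(=O)c3ccccc3)ccc2C(F)(F)F)CC1` gives 350 nM. Compound 1 therefore stands second of the three numbers; its gap to compound 2 is a 1.1-fold lower number from compound 1 to compound 2 (0.05 log units; within the scatter), and the gap from compound 2 onward to compound 3 is a 1.4-fold higher number from compound 2 to compound 3 (0.15 log units; within the scatter), so the three sit within the scatter of one another.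

Compound 4 `CCNC(=O)N1CCC[C@H]1C(=O)N1CCC(NS(=O)(=O)c2cc(S(=O)(=O)c3ccccc3)ccc2C(F)(F)F)CC1` is not yet measured. It differs from compound 1 as follows: 1-(ethylcarbamoyl)pyrrolidin-2-yl in place of (dimethylamino)methyl on a carbonyl carbon. The measured steps that bear on this are the move from compound 1 to compound 2, which showed a 1.1-fold lower number from compound 1 to compound 2 (0.05 log units; within the scatter), and the move from compound 2 to compound 3, which showed a 1.4-fold higher number from compound 2 to compound 3 (0.15 log units; within the scatter); neither exceeds the scatter, and compound 4 shares the pyrrolidine-bearing carbonyl of compound 2 while carrying an ethylcarbamoyl on the ring nitrogen. Among the compounds with values here, compound 2 with its acetyl gives 250 nM; no step from compound 2 to compound 4 has been measured. The expected step is a 1.0-fold lower number from compound 1 to compound 4 (0.02 log units; within the scatter), i.e. no change beyond the scatter. Compound 4 is estimated at 270 nM, within a range of 130 nM to 560 nM.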

Compound 4, half-maximal effective concentration: 90 nM
Compound 4: the middle estimate sits 3.0-fold (0.48 log units) above what was measured; the whole stated range lies above it.
By their numbers in this assay, from the lowest: compound 4; then compounds 2, 1 and 3 (each within the scatter of the next).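

In this assay, within the data shown here, the group on a carbonyl carbon whose other neighbour is an amide-type nitrogen in a ring had so far left the number within the scatter, but 1-(ethylcarbamoyl)pyrrolidin-2-yl in place of (dimethylamino)methyl gives a 3.1-fold lower number from compound 1 to compound 4 (0.49 log units; beyond the scatter). The shift traces to the group on the outer carbonyl rather than to the pyrrolidine alone: ethylamino in place of methyl gives a 2.8-fold lower number from compound 2 to compound 4 (0.44 log units; beyond the scatter), ethylamino in place of pyridin-4-yl gives a 3.9-fold lower number from compound 3 to compound 4 (0.59 log units; beyond the scatter), and the pyrrolidine with methyl on that carbonyl stays within the scatter of the (dimethylamino)methyl group. Nothing available on these compounds accounts for the size of this shift.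

Still open, from the compounds shown here alone, is whether the shift depends on the amide hydrogen of ethylamino or on the ethyl chain, which dimethylamino, methylamino or a longer chain such as propylamino on the same carbonyl would help to separate. Also open, going by these compounds, is how far the shift depends on the defined stereocentre of the pyrrolidine, which the opposite configuration of the same ethylcarbamoyl group would test.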